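From chloro to methoxy in compound 1

The source may hold more compounds than are shown below. What is called first, only, known or untested is meant among the compounds shown, and "the series" means these compounds.

Going by the values given here, in a functional assay on UO-31 cells (Homo sapiens) for inhibition (a higher number here means a weaker inhibitor of growth, a lower number a stronger inhibitor of growth), compound 1 (`COc1cc(/C=C/C(=O)c2cccc(-n3cc(-c4ccc(Cl)cc4)[nH]c3=O)c2)cc(OC)c1OC`) gives 7030 nM, the higher of the two numbers so far. Compound 2 (`COc1cc(/C=C/C(=O)c2cccc(-n3cc(-c4ccccc4)[nH]c3=O)c2)ccc1O`) gives 2180 nM, lower than compound 1 by more than the usual scatter. These two compounds differ in more than one place, so their gap does not isolate any single change.

Compound 3 (`COc1ccc(-c2cn(-c3cccc(C(=O)/C=C/c4cc(OC)c(OC)c(OC)c4)c3)c(=O)[nH]2)cc1`) is still unmeasured. It departs from compound 1 by methoxy in place of chloro on an aromatic carbon, para to a large group: methoxy in place of chloro on an aromatic carbon. The same difference reads 4-chlorophenyl to 4-methoxyphenyl. Among the compounds with values here, no measured pair shows this change, so the expectation is weakly anchored. In this assay, no step beyond the scatter is expected, with a slight lean towards a lower number: the estimated change is a 1.4-fold lower number from compound 1 to compound 3 (0.15 log units; within the scatter). For compound 3 the estimated value is 5000 nM, with an expected range of 2000 nM to 12000 nM.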

Compound 3, concentration for 50% growth inhibition: 1910 nM
Compound 3: the middle estimate sits 2.6-fold (0.42 log units) above what was measured, outside the stated range (below it).
By their numbers in this assay, from the lowest: compounds 3 and 2 (each within the scatter of the next); then compound 1.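

In this assay, this position now has its first direct reading: with the rest of compound 1 unchanged, methoxy in place of chloro on an aromatic carbon, para to a large group, gives a 3.7-fold lower number from compound 1 to compound 3 (0.57 log units; beyond the scatter) (modest). The change from 4-chlorophenyl to 4-methoxyphenyl alone therefore moves the number beyond the scatter, which the earlier gap between two compounds differing in more than one place could not isolate. No measurement at hand explains this step.

On these data alone, only chloro and methoxy have been read at this position on the core of compound 1, so it remains open whether the step would hold for other groups, such as an amine or a carboxylic acid. As far as these compounds go, it also remains open whether the same change gives a similar step on a different background.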